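The source may hold more compounds than are shown below. What is called first, only, known or untested is meant among the compounds shown, and "the series" means these compounds.

Measured in a functional assay on MDA-MB-231 cells (Homo sapiens) for cytotoxicity, read by MTT assay, with a stated time of 48 h; on this read-out higher numbers stand for weaker inhibition and lower numbers for stronger inhibition:
compound 1 `COC(=O)Cn1cc(CO[C@H]2CC(=O)[C@@H]3OC[C@H]2O3)nn1`: 21300 nM
compound 2 `O=C1C[C@H](OCc2cn(C(=O)c3ccccc3)nn2)[C@H]2CO[C@@H]1O2`: 25900 nM
compound 3 `O=C1C[C@H](OCc2cn(-c3ccc(Cl)cc3)nn2)[C@H]2CO[C@@H]1O2`: 26100 nM

Compound 3 carries the highest of the three numbers, yet both steps to it, a 1.2-fold higher number from compound 1 to compound 3 (0.09 log units; within the scatter) and a 1.0-fold higher number from compound 2 to compound 3 (0.00 log units; within the scatter), sit within the scatter, so the three compounds cannot be ordered. Compound 4 `O=C1C[C@H](OCc2cn(-c3ccc(F)cc3)nn2)[C@H]2CO[C@@H]1O2` differs from compound 3 by fluoro in place of chloro on an aromatic carbon. Among the measured compounds shown here, no measured step exchanges one halogen for another; the step closest in place is a 1.0-fold higher number from compound 2 to compound 3 (0.00 log units; within the scatter), which replaced the entire group on the aromatic nitrogen and produced no movement, as did a 1.2-fold higher number from compound 1 to compound 2 (0.08 log units; within the scatter). A single-atom exchange further out is therefore expected to give no step beyond the scatter, a 1.0-fold higher number from compound 3 to compound 4 (0.01 log units; within the scatter). Compound 4 is estimated at 27000 nM, with a range of 14000 nM to 55000 nM.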

Compound 4, half-maximal inhibitory concentration: 23700 nM
For compound 4 the middle estimate is 1.1-fold (0.06 log units) above the measured one; the measured number falls inside the stated range.
By their numbers in this assay, from the lowest: compounds 1, 4, 2 and 3 (each within the scatter of the next).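

In this assay the exchange of chloro for fluoro gives a 1.1-fold lower number from compound 3 to compound 4 (0.04 log units; within the scatter) and so does not separate these two halogens on this aromatic carbon, para to a large group. On the aromatic nitrogen, 4-fluorophenyl also stays within the scatter of benzoyl, with a 1.1-fold lower number from compound 2 to compound 4 (0.04 log units; within the scatter) as the step, and of (methoxycarbonyl)methyl, with a 1.1-fold higher number from compound 1 to compound 4 (0.05 log units; within the scatter) as the step.

Going by these compounds, whether an amine or a carboxylic acid on this aromatic carbon would give a step beyond the scatter stays open. No supporting evidence bears on these results.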